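From methyl to chloro in a small series

The source may report more compounds than this note shows. Statements on the series, on what has been measured and on what is new or still open speak of the compounds shown alone.

Values measured in a functional assay on A549 cells (Homo sapiens) for cytotoxicity, read by MTT assay, with a stated time of 68 h; a higher number here means a weaker inhibitor, a lower number a stronger inhibitor:
compound 1 `COc1cccc(-c2cccc(NC(=O)C(Cl)Cl)c2)c1`: 4310 nM
compound 2 `O=C(Nc1cccc(-c2cccc(C(F)(F)F)c2)c1)C(Cl)Cl`: 18500 nM
compound 3 `Cc1cccc(-c2cccc(NC(=O)C(Cl)Cl)c2)c1`: 8700 nM

Among these three, compound 3 stands in the middle at 8700 nM, with compound 1 lower and compound 2 higher. The next compound, compound 4 `O=C(Nc1cccc(-c2cccc(Cl)c2)c1)C(Cl)Cl`, has chloro in place of methyl on an aromatic carbon. Within the data shown here, no measured step makes this exact swap, and no measured compound here carries chloro at this spot, so the closest guides are the steps among the three measured compounds. These are a 2.0-fold higher number from compound 1 to compound 3 (0.31 log units; beyond the scatter), a 2.1-fold lower number from compound 2 to compound 3 (0.33 log units; beyond the scatter) and, spanning the whole range, a 4.3-fold higher number from compound 1 to compound 2 (0.63 log units; beyond the scatter). All are modest, though beyond the usual scatter. In this assay, a step no larger than these is therefore expected, most likely none beyond the scatter and with no clear direction. The expected change is a 1.0-fold higher number from compound 3 to compound 4 (0.01 log units; within the scatter). For compound 4 the estimated value is 9000 nM, with an expected range from 4000 nM to 20000 nM.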

Compound 4, half-maximal inhibitory concentration: 21400 nM
Compound 4: middle estimate off by 2.4-fold (0.38 log units), on the low side, and the stated range ends below it.
By their numbers in this assay, from the lowest: compound 1; then compound 3; then compounds 2 and 4 (each within the scatter of the next).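

Chloro at this spot on an aromatic carbon does not act as a simple stand-in for methyl, even though the two match in their counts of heavy atoms, donors and acceptors: in this assay the swap gives a 2.5-fold higher number from compound 3 to compound 4 (0.39 log units; beyond the scatter), a modest but real step. Chloro instead lands with trifluoromethyl, as a 1.2-fold higher number from compound 2 to compound 4 (0.06 log units; within the scatter) is within the scatter, so this assay does not separate these two groups. Methoxy keeps the lowest number of the four, with a 5.0-fold higher number from compound 1 to compound 4 (0.70 log units; beyond the scatter), the widest step in the set.

Nothing shown gives a reason for these steps. As far as these compounds go, it also remains open whether an amine or a carboxylic acid at this spot would join methoxy at the low end or sit with chloro and trifluoromethyl.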